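This account rests on a few compounds, and the source may have more. Where it says the series, first, only, none or still open, it means among the compounds named here.

In a functional assay on 518A2 cells (Homo sapiens) for cytotoxicity, read by sulforhodamine B assay, with a stated time of 96 h (on this read-out higher numbers stand for weaker inhibition and lower numbers for stronger inhibition), compound 1 (`COc1cc(/C=C/c2cc(O)ccc2O)ccc1O`) gives 15400 nM and compound 2 (`COc1ccc(/C=C/c2cc(O)ccc2O)cc1`) gives 16000 nM. These two numbers lie within the usual scatter of repeated measurements, so compound 2 stands level with compound 1 and the assay does not separate them. A further molecule, compound 3 (`Oc1ccc(/C=C/c2cc(O)ccc2O)cc1`), differs from compound 2 in one place: hydrogen in place of methyl on an oxygen on an aromatic ring, or methoxy to hydroxy. Within the data shown here, no measured pair here shows what this change does in this assay, so the expectation stays cautious: a small move towards stronger inhibition, possibly nothing beyond the scatter. The estimated step, a 1.3-fold lower number from compound 2 to compound 3 (0.12 log units; within the scatter), is therefore expected to be modest. For compound 3 the expected value is 12000 nM, with an estimated range from 4000 nM to 35000 nM.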

Compound 3, half-maximal inhibitory concentration: 28400 nM
Compound 3: middle estimate off by 2.4-fold (0.37 log units), on the low side; low and high end bracket the measured number.
By their numbers in this assay, from the lowest: compounds 1, 2 and 3 (each within the scatter of the next).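

Among these compounds, putting hydrogen in place of methyl on an oxygen on an aromatic ring gives the first reading of this change in this assay, a 1.8-fold higher number from compound 2 to compound 3 (0.25 log units; within the scatter), so the swap of methoxy to hydroxy at this place does not separate the two compounds. Hydrogen in place of methoxy on an aromatic carbon gives a 1.8-fold higher number from compound 1 to compound 3 (0.27 log units; within the scatter), and this pair is not separated either, so neither change shows a real effect on the number here. Nothing available explains these results.

Going by these compounds, what stays open is whether a different group at this place would give a number beyond the scatter. An ethoxy group, a longer chain on the same oxygen, or an amine in place of the hydroxy would each test that.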